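The compounds below may be only part of what the source reports. "The series", "measured", "known", "first", "only" and "open" are said of these compounds alone.

The measured compounds:
compound 1, `COc1cc(OC)c2c(=O)cc(/C=C/c3ccc([N+](=O)[O-])cc3)oc2c1`, 9600 nM;
compound 2, `COc1ccc2oc(/C=C/c3ccc(OC(F)(F)F)cc3)cc(=O)c2c1`, 9000 nM;
compound 3, `COc1cc(OC)c2c(=O)cc(/C=C/c3ccncc3)oc2c1`, 18800 nM.

In a functional assay on HeLa cells (Homo sapiens) for antiproliferative activity, read by MTT assay, with a stated time of 12 h (on this read-out higher numbers stand for weaker inhibition and lower numbers for stronger inhibition), compound 1 gives the second highest of the three numbers; compound 2 sits nearest to it and compound 3 furthest, yet both gaps lie within the usual scatter, so the three cannot be put in any order. Compound 4, `COc1cc(OC)c2c(=O)cc(/C=C/c3ccc(OCC4CC4)cc3)oc2c1`, has not been measured. It differs from compound 1 in one place: cyclopropylmethoxy in place of nitro on an aromatic carbon. No step between measured compounds covers such a change, so the expectation rests on the weak numbers shown alone. Compound 4 is expected to stay close to compound 1, with a step of a 1.3-fold lower number from compound 1 to compound 4 (0.11 log units; within the scatter) that is not expected to reach beyond the scatter. The estimate for compound 4 is 7500 nM, within 2500 nM to 22000 nM.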

Compound 4, half-maximal inhibitory concentration: 10900 nM
For compound 4 the middle estimate is 1.5-fold (0.16 log units) below the measured one; measured number inside the range.
By their numbers in this assay, from the lowest: compounds 2, 1, 4 and 3 (each within the scatter of the next, the first and the last beyond it).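

In this assay the exchange of nitro for cyclopropylmethoxy, on an aromatic carbon para to a large group, gives a 1.1-fold higher number from compound 1 to compound 4 (0.06 log units; within the scatter) and stays within the scatter. This is the first step in one place among these compounds, and it shows that the two groups, though different in size and make-up, cannot be told apart at this position by this read-out. No measurement shown here offers a reason for this result.

As far as these compounds go, whether an amine, a carboxylic acid or a longer chain at this position would move the number beyond the scatter remains open.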